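The source may report more compounds than this note shows. Statements on the series, on what has been measured and on what is new or still open speak of the compounds shown alone.

Compound 1 `CCCCCCCCCCCCC/C=C/[C@@H](O)[C@H](CO)n1cc(CCC)nn1` gives 15700 nM in a functional assay on NCI-H358 cells (Homo sapiens) for cytotoxicity, read by sulforhodamine B assay; on this read-out higher numbers stand for an effect only at larger amounts of compound and lower numbers for an effect already at smaller amounts. For compound 2 `CCCCCCCCCCCCC/C=C/[C@@H](O)[C@H](CO)n1cc(CCCCCCCCCCCCC)nn1` this assay reports only a limit, > 50000 nM. The step of an at least 3.1-fold higher number from compound 1 to compound 2 (0.50 log units; beyond the scatter) thus runs into the ceiling of the run (the limit of > 50000 nM in this assay, at which 1 of the 2 values shown sits), so compound 2 stands at the high end of the numbers shown, without a number of its own. Compound 3 `CCCCCCCCCCCCC/C=C/[C@@H](O)[C@H](CO)n1cc(CCCCCCCCCCCCCCCCCCCCCCCC)nn1` extends that same chain further: undecyl in place of hydrogen on a saturated chain carbon, ten or more bonds along the chain from an aromatic carbon. Within the data shown here, only the step from compound 1 to compound 2 bears on this change, and it already reached the limit; a still longer chain is expected to leave the read-out at or beyond that limit, a step that the limit leaves unreadable from compound 2 to compound 3. Compound 3 is estimated at 100000 nM, between 50000 nM and 300000 nM.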

Compound 3, half-maximal effective concentration: > 50000 nM
Compound 3 gave a limit, no number; the forecaster's own chance of this, stated with the estimate: 85%; the middle value lies beyond the limit too.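

Among these compounds, compound 2 and compound 3 both give only a limit, not a number, so no step between them can be read: the limit of > 50000 nM in this assay, at which 2 of the 3 values shown sit. The compounds shown leave open where compound 2 and compound 3 truly stand, and whether the added undecyl changes the read-out at all.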